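A few compounds are considered here, and "the series" means these few. Any claim that something is new, unique, unknown or untested is made for them only; others in the source may bear on it.

The series shares one core, seen in compound 1 `COc1ccc2ccc(=O)oc2c1C1=NN(C(C)=O)C(c2ccc(SC)cc2)C1`, compound 2 `COc1ccc2ccc(=O)oc2c1C1=NNC(c2ccc(SC)cc2)C1` and compound 3 `COc1ccc2ccc(=O)oc2c1C1=NN(c2ccccc2)C(c2cccs2)C1`. In a functional assay on HepG2 cells (Homo sapiens) for cytotoxicity, read by MTT assay, with a stated time of 72 h (on this read-out lower numbers stand for stronger inhibition and higher numbers for weaker inhibition), compound 1 gives 42 nM, compound 2 gives 10 nM and compound 3 gives 15 nM. For the measured compounds named here, the only single-point step measured so far, a 4.2-fold lower number from compound 1 to compound 2 (0.62 log units; beyond the scatter), concerns the ring nitrogen and not the saturated ring carbon. Compound 3 stands second highest of the three numbers; its nearest neighbour is compound 2, whose value lies within the scatter of it, while compound 1 lies beyond the scatter above it. Compound 4 `COc1ccc2ccc(=O)oc2c1C1=NN(c2ccccc2)C(c2ccc(SC)cc2)C1` differs from compound 3 by 4-(methylsulfanyl)phenyl in place of thiophen-2-yl on a saturated ring carbon. Going by the values given here, no measured step bears on this exchange: compound 2 carries the entering group, but it also carries a hydrogen on the ring nitrogen, so its value set against compound 3 mixes two changes and cannot be read as a clean step. The step of a 1.3-fold lower number from compound 3 to compound 4 (0.10 log units; within the scatter) is therefore expected to stay within the scatter, with no direction implied. Compound 4 is estimated at 12 nM in this assay, with a range from 5 nM to 35 nM.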

Compound 4, half-maximal inhibitory concentration: 78 nM
Compound 4: the middle estimate sits 6.5-fold (0.81 log units) below what was measured; measured number outside the range, above it.
By their numbers in this assay, from the lowest: compounds 2 and 3 (each within the scatter of the next); then compounds 1 and 4 (each within the scatter of the next).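

In this assay, the saturated ring carbon responds to its substituent: with phenyl on the ring nitrogen, 4-(methylsulfanyl)phenyl in place of thiophen-2-yl gives a 5.2-fold higher number from compound 3 to compound 4 (0.72 log units; beyond the scatter). With 4-(methylsulfanyl)phenyl held on that carbon, the ring nitrogen also matters: phenyl in place of hydrogen gives a 7.8-fold higher number from compound 2 to compound 4 (0.89 log units; beyond the scatter), while phenyl in place of acetyl gives a 1.9-fold higher number from compound 1 to compound 4 (0.27 log units; within the scatter), which leaves phenyl and acetyl unseparated there. Nothing available explains these steps.

Compound 3 is the only compound shown with thiophen-2-yl, so it remains open whether the exchange on the saturated ring carbon would read the same with hydrogen or acetyl on the ring nitrogen. Also open, going by these compounds, is how an unsubstituted phenyl, or a phenyl bearing an amine or a carboxylic acid, would read on that carbon.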